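A few compounds are considered here, and "the series" means these few. Any claim that something is new, unique, unknown or untested is made for them only; others in the source may bear on it.

Of the compounds shown here, three have been tested in a toxicity assay on NIH3T3 cells (Mus musculus) for cytotoxicity, read by resazurin assay (a lower number here means that less compound is needed, a higher number that more compound is needed for the effect), so far. Compound 1 `Cc1cccc(-c2cccc(NCc3cncn3Cc3ccccc3)c2)c1C` gives a reading that is only a limit of the assay, namely > 1000 nM. Compound 2 `COC(=O)c1ccc(NCc2cncn2Cc2ccc(N)cc2)cc1-c1ccccc1` also gives only a limit, here > 10000 nM. Compound 3 `O=C(c1ccc(NCc2cncn2Cc2ccc(-c3ccccc3)cc2)cc1-c1ccccc1)N1CCCCC1` likewise returns no number but a limit, > 1000 nM.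

So compound 3 cannot be placed above or below the other two: all three sit at limits, and the picture is described by the limit of > 1000 nM in this assay, at which 2 of the 3 values shown sit, and by the limit of > 10000 nM in this assay, at which 1 of the 3 values shown sits. Nothing among these values points to a compound that damages the cells more than the others.

Compound 4 `CNC(=O)c1ccc(NCc2cncn2Cc2ccc(-c3ccccc3)cc2)cc1-c1ccccc1` is the next one to go into this assay. It differs from compound 3 in one place only, (methylamino in place of piperidin-1-yl on a carbonyl carbon). Among the measured compounds shown here, no pair of measured compounds shows what this kind of change does in this assay, so there is no measured step to lean on.

Given that compound 3 gives only a limit of > 1000 nM, the step that the limit leaves unreadable from compound 3 to compound 4 is expected to be none beyond the usual scatter, with the reading most likely again a limit. Compound 4 is therefore estimated at 3000 nM, with a range from 1000 nM to 30000 nM.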

Compound 4, half-maximal effective concentration: > 1000 nM
Compound 4 was reported as a limit; the forecaster's own chance of this, stated with the estimate: 85%; the middle value is on the limit's open side.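

Compound 3 and compound 4 both return only a limit of the assay rather than a number in this assay, so the step between them cannot be read. The compounds shown leave open whether methylamino in place of piperidin-1-yl on a carbonyl carbon changes cytotoxicity at all, and at what concentration any of these compounds would affect the cells.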